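This account rests on a few compounds, and the source may have more. Where it says the series, first, only, none or still open, it means among the compounds named here.

Measured in an ADME assay on U2OS cells (Homo sapiens) for cytotoxicity; on this read-out higher numbers stand for lower toxicity in this test and lower numbers for higher toxicity in this test:
- compound 1 `O=C(N/N=C/c1ccc([N+](=O)[O-])o1)c1cccs1`: 57200 nM
- compound 2 `CCCCc1ccc(C(=O)N/N=C/c2ccc([N+](=O)[O-])o2)cc1`: 19600 nM

Of these two, compound 2 has the lower number, which makes it the more toxic in this test. Compound 1 stands higher, and the gap between them is beyond the usual scatter of repeated measurements. However, the two compounds differ in more than one place, so their gap cannot be pinned on any single group.

Compound 3 `O=C(N/N=C/c1ccc([N+](=O)[O-])o1)c1ccc(-c2ccccc2)cc1` is compound 2 with phenyl in place of butyl on an aromatic carbon, para to a large group: phenyl in place of butyl on an aromatic carbon. Neither group carries a hydrogen-bond donor, a hydrogen-bond acceptor or a net charge. Within the data shown here, no measured pair shows this kind of swap, so the expectation is a cautious one. With compound 2 at 19600 nM as the closest reference, no change beyond the scatter is expected in this assay, and a direction cannot be called with confidence. The estimated step is a 1.1-fold lower number from compound 2 to compound 3 (0.04 log units; within the scatter). The expected value for compound 3 is 18000 nM, within an estimated range of 6000 nM to 50000 nM.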

Compound 3, half-maximal cytotoxic concentration: 109000 nM
Compound 3: the middle estimate sits 6.1-fold (0.78 log units) below what was measured; the whole stated range lies below it.
By their numbers in this assay, from the lowest: compound 2; then compounds 1 and 3 (each within the scatter of the next).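

In this assay, putting phenyl in place of butyl on this aromatic carbon, para to a large group, gives a 5.6-fold higher number from compound 2 to compound 3 (0.75 log units; beyond the scatter), so the change moves the read-out towards lower toxicity in this test. Among these compounds, this is the first comparison here that rests on a change in one place only, since compounds 1 and 2 differ in more than one, and it shows that the group held at this position matters even when neither group carries a hydrogen-bond donor, a hydrogen-bond acceptor or a net charge. Nothing measured here explains why the number moves with this swap.

A single step cannot separate the effect of the aromatic ring from that of the larger number of heavy atoms, as phenyl differs from butyl in both respects and the two always travel together in this pair. A cyclohexyl group or a longer chain at the same place would help to pull those two apart, while an amine there would test whether the trend holds for a group of a quite different kind.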